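The source may hold more compounds than are shown below. What is called first, only, known or untested is meant among the compounds shown, and "the series" means these compounds.

Series so far in a functional assay on HCC827 cells (Homo sapiens) for antiproliferative activity, read by MTT assay, with a stated time of 72 h; a higher number here means a weaker inhibitor, a lower number a stronger inhibitor

Compound 1 `CC(C)n1c(Sc2ccccc2)nc2cnc(Nc3ccc(N4CCN(C)CC4)cc3)nc21` gives 290 nM
Compound 2 `CN1CCN(c2ccc(Nc3ncc4nc(Sc5ccccc5)n(C5CCCC5)c4n3)cc2)CC1` gives 51.2 nM

Compound 2 holds the lower of the two numbers, with compound 1 as its nearest neighbour. Next is compound 3 `CN1CCN(c2ccc(Nc3ncc4nc(Sc5ccccc5)n(CC5CC5)c4n3)cc2)CC1`, which keeps the shared core and differs from compound 2 by the change cyclopropylmethyl in place of cyclopentyl on an aromatic nitrogen with cyclopropylmethyl in place of cyclopentyl on an aromatic nitrogen. Going by the values given here, one measured step bears on this, namely a 5.7-fold lower number from compound 1 to compound 2 (0.75 log units; beyond the scatter) for cyclopentyl in place of isopropyl, a modest step beyond the scatter. Among the compounds with values here, no cyclopropylmethyl compound has been measured, so the expectation rests on that step alone. A modest move to a higher number is expected in this assay, giving back part of that fall, and the estimated size is a 2.3-fold higher number from compound 2 to compound 3 (0.37 log units; beyond the scatter) for this change. Compound 3 is expected at 120 nM within an estimated range of 40 nM to 350 nM for now.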

Compound 3, half-maximal inhibitory concentration: 660 nM
For compound 3 the middle estimate is 5.5-fold (0.74 log units) below the measured one, outside the stated range (above it).
By their numbers in this assay, from the lowest: compound 2; then compound 1; then compound 3.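

In this assay, the group on the aromatic nitrogen proves more decisive than the first pair suggested: cyclopropylmethyl in place of cyclopentyl gives a 13-fold higher number from compound 2 to compound 3 (1.11 log units; beyond the scatter), a large step. Cyclopropylmethyl in place of isopropyl gives a 2.3-fold higher number from compound 1 to compound 3 (0.36 log units; beyond the scatter), so the order at this position runs cyclopentyl, isopropyl, cyclopropylmethyl, and a carbon ring in the group does not by itself secure the lowest number, since compound 2 and compound 3 both carry one. Nothing available accounts for this order.

Whether the low number is specific to cyclopentyl remains open, as the compounds shown do not include cyclobutyl, cyclohexyl or an oxygen-containing ring such as tetrahydropyranyl at this position. Also open, on these data alone, is whether the same order would hold with a benzyl group in place of phenylsulfanyl.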